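Series notes: naphthalen-2-yl replacing bromo on compound 1

The compounds below may be only part of what the source reports. "The series", "measured", "known", "first", "only" and "open" are said of these compounds alone.

Compound 1, `CC1CCN(C2CCN(S(=O)(=O)c3cccc(Br)c3)CC2)CC1`, is the reference point of this set. In an ADME assay on HCT-116 cells (Homo sapiens) for cytotoxicity, read by CellTiter-Glo, with a stated time of 72 h (a lower number here means a stronger inhibitor, a higher number a weaker inhibitor), compound 1 gives > 5000 nM, which is a limit of the assay and not a measured number. Compound 2, `COc1ccc(Br)cc1S(=O)(=O)N1CCC(N2CCC(C)CC2)CC1`, carries a methoxy in place of hydrogen on an aromatic carbon; compound 2 gives > 5000 nM, again a limit. Compound 3, `CC1CCN(C2CCN(S(=O)(=O)c3ccc(Cl)cc3Cl)CC2)CC1`, carries 2,4-dichlorophenyl in place of 3-bromophenyl on a sulfonyl sulfur; compound 3 gives > 5000 nM, also a limit. The two one-place steps are therefore a step that the two limits leave unreadable from compound 1 to compound 2 and a step that the two limits leave unreadable from compound 1 to compound 3, neither of which can be sized, because of the limit of > 5000 nM in this assay, at which 3 of the 3 values shown sit.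

Compound 4, `CC1CCN(C2CCN(S(=O)(=O)c3cccc(-c4ccc5ccccc5c4)c3)CC2)CC1`, is not yet measured. Its change from compound 1 is naphthalen-2-yl in place of bromo on an aromatic carbon. Among the compounds with values here, no measured step in this set touches the position of the bromo or introduces a ring of comparable size, so neither step bears on it beyond showing that the series has so far stayed at the limit. The expectation for compound 4 is accordingly that it sits close to the limit as well, estimated at 6000 nM with a range of 1500 nM to 25000 nM, which means an expected step that the limit leaves unreadable from compound 1 to compound 4.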

Compound 4, half-maximal inhibitory concentration: > 5000 nM
Compound 4 gave a limit, no number; the forecaster's own chance of this, stated with the estimate: 65%; the middle value does not contradict the limit.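

In this assay compound 4 gives > 5000 nM, a limit of the assay and not a number. The change from compound 1 to compound 4 therefore cannot be sized, because both compounds share one ceiling: the limit of > 5000 nM in this assay, at which 4 of the 4 values shown sit. The compounds shown leave open how far any of them lies beyond that limit, and which change would give a measurable value.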